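The compounds below may be only part of what the source reports. "The series", "measured", "known", "first", "only" and "open" are said of these compounds alone.

In a functional assay on MGC-803 cells (Homo sapiens) for antiproliferative activity, read by CCK-8 assay, with a stated time of 72 h, tested at 2 uM (on this read-out lower numbers stand for a weaker effect and higher numbers for a stronger effect at the one concentration tested), compound 1 `Nc1ccccc1NC(=O)c1ccc(CSC(=S)N2CCN(c3ccccc3)CC2)cc1` gives 42.3%, compound 2 `Nc1ccccc1NC(=O)c1ccc(CSC(=S)N2CCN(c3ccc(F)cc3)CC2)cc1` gives 18.8%, and compound 3 `N#Cc1ccc(N2CCN(C(=S)SCc3ccc(C(=O)Nc4ccccc4N)cc3)CC2)cc1` gives 34.5%. Compound 3 thus stands second highest of the three: its gap to compound 1 is within the scatter, while it lies beyond the scatter above compound 2. Compound 4 `Cc1ccc(N2CCN(C(=S)SCc3ccc(C(=O)Nc4ccccc4N)cc3)CC2)cc1` differs from compound 3 by methyl in place of cyano on an aromatic carbon. Among the measured compounds shown here, no measured step brings in a methyl group. The steps that touch the same aromatic carbon are a number 7.8 percentage points lower from compound 1 to compound 3 (within the scatter), a number 15.7 percentage points higher from compound 2 to compound 3 (beyond the scatter) and a number 23.5 percentage points lower from compound 1 to compound 2 (beyond the scatter), so small groups at this place have moved this assay in both directions by modest amounts. Compound 4 is therefore expected to show a step of a number 1.5 percentage points lower from compound 3 to compound 4 (within the scatter) in this assay, and its estimated value is 33%, with a range from 15% to 50%.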

Compound 4, a percentage reported as inhibition, at one concentration (the size of the read-out at that concentration, not a potency): 33.4%
Beside the measured number, compound 4's estimate is 0.4 percentage points below it; low and high end bracket the measured number.
By their numbers in this assay, from the lowest: compound 2; then compounds 4, 3 and 1 (each within the scatter of the next).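

Methyl in place of cyano on this aromatic carbon gives a number 1.1 percentage points lower from compound 3 to compound 4 (within the scatter), and methyl in place of hydrogen gives a number 8.9 percentage points lower from compound 1 to compound 4 (within the scatter), so in this assay methyl, cyano and hydrogen sit together within the scatter. Fluoro alone stands apart among these groups, as methyl in place of fluoro gives a number 14.6 percentage points higher from compound 2 to compound 4 (beyond the scatter). Nothing available explains why fluoro differs. As far as these compounds go, it remains open whether chloro, another halogen, would follow fluoro at this place. From the compounds shown here alone, an amine, a methoxy group or a carboxylic acid there also remains open.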